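This account rests on a few compounds, and the source may have more. Where it says the series, first, only, none or still open, it means among the compounds named here.

Measured in a functional assay on MCF7 cells (Homo sapiens) for inhibition, read by radiometric assay and XTT assay; on this read-out higher numbers stand for weaker inhibition and lower numbers for stronger inhibition:
- Compound 1 `C=C/C(C)=C/[C@@]1(C)SC(=O)C=C1O`: > 80 ug/mL, a limit.
- Compound 2 `CCCCCC[C@@]1(C)SC(O)=CC1=O`: > 80 ug/mL, a limit.
- Compound 3 `CCCCCCCC[C@@]1(C)SC(O)=CC1=O`: 17.6 ug/mL.

Compound 3 holds the only number shown. Compound 1 and compound 2 stand at the limit of > 80 ug/mL in this assay, at which 2 of the 3 values shown sit.

Compound 4 `CCCCCCCC[C@@]1(C)SC(O)=C(C(C)=O)C1=O` differs from compound 3 by acetyl in place of hydrogen on a double-bonded ring carbon. For the measured compounds named here, the only measured step, an at least 4.5-fold lower number from compound 2 to compound 3 (0.65 log units; beyond the scatter), lies on the chain and not at this place, so it sets neither size nor direction here. In this assay no shift beyond the scatter is therefore expected, with a wide margin on both sides. The expected step is a 1.1-fold higher number from compound 3 to compound 4 (0.06 log units; within the scatter). For compound 4 the estimated value is 20 ug/mL, with an expected range of 6 ug/mL to 70 ug/mL.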

Compound 4, half-maximal inhibitory concentration: 12.5 ug/mL
Compound 4: middle estimate off by 1.6-fold (0.20 log units), on the high side; the measured number falls inside the stated range.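

For the compounds shown here, the first reading on the ring rather than the chain is acetyl in place of hydrogen on a double-bonded ring carbon, which gives a 1.4-fold lower number from compound 3 to compound 4 (0.15 log units; within the scatter). In this assay this position therefore accepts acetyl, with the chain of compound 3 kept, without a shift beyond the scatter. Compound 4, like compound 3, gives a number and not a limit: the limit of > 80 ug/mL in this assay, at which 2 of the 4 values shown sit.

Still open, going by these compounds, is whether a larger acyl group, an amine or a carboxylic acid at this ring carbon would keep the number in the same range. Also open, on these data alone, is whether a longer chain would add to what the chain step showed.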